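Shortening the amide side chain: tolerance on THP-1 cells

A few compounds are considered here, and "the series" means these few. Any claim that something is new, unique, unknown or untested is made for them only; others in the source may bear on it.

The series is built on three amides: compound 1 `COc1ccc(-c2cnc(NC(=O)C3CCCC3)n2C)cc1`, compound 2 `COc1ccccc1-c1cnc(NC(=O)c2ncc[nH]2)n1C` and compound 3 `COc1ccc2c(c1)nc(NC(=O)c1ccc(F)cc1)n2C`. In a toxicity assay on THP-1 cells (Homo sapiens) for inhibition (a higher number here means that more compound is tolerated, a lower number that less compound is tolerated), compound 1 reaches only a limit, > 100000 nM. Compound 2 likewise gives only a limit, > 50000 nM. Compound 3 also stays at a limit, > 100000 nM. Within the data shown here, two of the three values sit at the limit of > 100000 nM in this assay, at which 2 of the 3 values shown sit, and one at the limit of > 50000 nM in this assay, at which 1 of the 3 values shown sits, so no step between measured compounds can be drawn.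

Compound 4 `CCC(=O)Nc1ncc(-c2ccc(OC)cc2)n1C` is not yet measured. It differs from compound 1 by ethyl in place of cyclopentyl on a carbonyl carbon.

Because compound 1 gives > 100000 nM, the expected step of a number no higher from compound 1 to compound 4 (the limit leaves the size open) is none beyond the scatter. For compound 4 the expected value in this assay is 100000 nM, within 50000 nM to 200000 nM, most likely reported again as a limit.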

Compound 4, half-maximal cytotoxic concentration: > 100000 nM
Compound 4: only a limit was reported; the forecaster's own chance of this, stated with the estimate: 85%; the middle value lies on the limit itself.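

Compound 1 and compound 4 both give only a limit, and no step between them can be read: the limit of > 100000 nM in this assay, at which 3 of the 4 values shown sit.

The compounds shown leave open at what concentration any of them stops being tolerated in this assay.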